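The source may report more compounds than this note shows. Statements on the series, on what has been measured and on what is new or still open speak of the compounds shown alone.

Measured so far:
Compound 1 `O=C1N=C(N2N=C(c3ccccc3)CC2c2ccccc2O)S/C1=C1/C(=O)Nc2ccccc21`: 2030 nM
Compound 2 `O=C1N=C(N2N=C(c3ccccc3)CC2c2ccccc2O)S/C1=C1/C(=O)Nc2ccc(Br)cc21`: 240 nM

In a functional assay on cells (Cancer cell lines, Homo sapiens) for cytotoxicity, read by sulforhodamine B assay, with a stated time of 48 h (on this read-out lower numbers stand for stronger inhibition of growth and higher numbers for weaker inhibition of growth), compound 1 stands highest of the two numbers shown; the only other compound, compound 2, sits an 8.5-fold lower number from compound 1 to compound 2 (0.93 log units; beyond the scatter) from it. Compound 3 `COc1ccc(C2CC(c3ccccc3)=NN2C2=NC(=O)/C(=C3\C(=O)Nc4ccccc43)S2)cc1` differs from compound 1 in one place, 4-methoxyphenyl in place of 2-hydroxyphenyl on a saturated ring carbon. Within the data shown here, the single measured step concerns a different part of the shared core, so nothing measured bears directly on this change. The expected step is therefore none beyond the scatter, a 1.0-fold lower number from compound 1 to compound 3 (0.01 log units; within the scatter), with a wide range. Compound 3 is estimated at 2000 nM, between 500 nM and 8000 nM.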

Compound 3, concentration for 50% growth inhibition: 2380 nM
Compound 3: middle estimate off by 1.2-fold (0.08 log units), on the low side; the range from low to high includes it.
By their numbers in this assay, from the lowest: compound 2; then compounds 1 and 3 (each within the scatter of the next).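

In this assay, the step is a 1.2-fold higher number from compound 1 to compound 3 (0.07 log units; within the scatter) when 4-methoxyphenyl replaces 2-hydroxyphenyl on the saturated ring carbon, so this exchange leaves the two compounds within the usual scatter. This position therefore accepts one substituted phenyl in place of the other without a measurable difference in growth inhibition. Nothing available explains why the two read alike.

The group and its place on the phenyl ring change together here. 2-methoxyphenyl or 4-hydroxyphenyl would be needed to separate the two. Going by these compounds, whether a non-aromatic group, such as an amine or a longer chain, would fare the same at this carbon remains open.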